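Swapping Chloro for Methyl on a Cytotoxic Scaffold

This account rests on a few compounds, and the source may have more. Where it says the series, first, only, none or still open, it means among the compounds named here.

Of the compounds shown here, two have been measured in a functional assay on K562/Adr cells (Homo sapiens) for cytotoxicity, read by sulforhodamine B assay, with a stated time of 48 h; on this read-out higher numbers stand for weaker inhibition and lower numbers for stronger inhibition. Compound 1 `CCN(CC)CCCn1c(=O)/c(=C/c2ccccc2O)s/c1=C1/C(=O)Nc2ccc(C)cc21` gives 30600 nM, while compound 2 `CCN(CC)CCCn1c(=O)/c(=C/c2cc(OC)c(OC)c(OC)c2)s/c1=C1/C(=O)Nc2ccc(Cl)cc21` gives 1650 nM, the lower of the two numbers, and the gap between them lies beyond the usual scatter. Compound 3 `CCN(CC)CCCn1c(=O)/c(=C/c2cc(OC)c(OC)c(OC)c2)s/c1=C1/C(=O)Nc2ccc(C)cc21` differs from compound 2 at one place: methyl in place of chloro on an aromatic carbon. Among the compounds with values here, no measured pair isolates this exchange, so the direction of the step is uncertain. The step from compound 2 to compound 3 in this assay is expected to be small, a 1.5-fold higher number from compound 2 to compound 3 (0.18 log units; within the scatter), likely within or near the scatter. Compound 3 is estimated at 2500 nM, within a range of 800 nM to 8000 nM.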

Compound 3, half-maximal inhibitory concentration: 2020 nM
Beside the measured number, compound 3's estimate is 1.2-fold (0.09 log units) above it; low and high end bracket the measured number.
By their numbers in this assay, from the lowest: compounds 2 and 3 (each within the scatter of the next); then compound 1.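

In this assay methyl and chloro on this aromatic carbon cannot be told apart, with a 1.2-fold higher number from compound 2 to compound 3 (0.09 log units; within the scatter) as the whole step. The large change lies elsewhere: 3,4,5-trimethoxyphenyl in place of 2-hydroxyphenyl on the double-bonded chain carbon gives a 15-fold lower number from compound 1 to compound 3 (1.18 log units; beyond the scatter) on the same core. Nothing measured here explains either step.

Going by these compounds, whether an amine or a carboxylic acid on this aromatic carbon would shift the number remains open. On these data alone, it is also open whether methyl and chloro would still match with 2-hydroxyphenyl on the chain.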